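The source may hold more compounds than are shown below. What is called first, only, known or untested is meant among the compounds shown, and "the series" means these compounds.

The measured compounds:
compound 1, `CN(C)CCn1cnnc1-c1cc(Oc2ccc(NC(=O)N/N=C/c3ccc(Cl)cc3Cl)cc2F)ccn1`, 810 nM
compound 2, `CN(C)CCn1cnnc1-c1cc(Oc2ccc(NC(=O)N/N=C/c3c(Cl)cccc3Cl)cc2F)ccn1`, 1410 nM
compound 3, `COc1ccc(/C=N/NC(=O)Nc2ccc(Oc3ccnc(-c4nncn4CCN(C)C)c3)c(F)c2)c(OC)c1OC`, 6680 nM

All three numbers come from a functional assay on A549 cells (Homo sapiens) for cytotoxicity, read by MTT assay, with a stated time of 72 h; on this read-out lower numbers stand for stronger inhibition and higher numbers for weaker inhibition. Compound 1 gives the lowest of them; its nearest neighbour is compound 2, with a 1.7-fold higher number from compound 1 to compound 2 (0.24 log units; within the scatter), a step within the scatter, so no order can be read between those two. The step to compound 3 is larger, an 8.2-fold higher number from compound 1 to compound 3 (0.92 log units; beyond the scatter), beyond the scatter, and the same group gives a 4.7-fold higher number from compound 2 to compound 3 (0.68 log units; beyond the scatter). For the measured compounds named here, the unmeasured compound 4, `COc1cc(/C=N/NC(=O)Nc2ccc(Oc3ccnc(-c4nncn4CCN(C)C)c3)c(F)c2)cc(OC)c1OC`, differs from compound 1 in one place: 3,4,5-trimethoxyphenyl in place of 2,4-dichlorophenyl on a carbon with a double bond to nitrogen The measured step most like this is the one from compound 1 to compound 3, where a 2,3,4-trimethoxyphenyl replaced the 2,4-dichlorophenyl on the carbon with a double bond to nitrogen and the number rose beyond the scatter. The two trimethoxyphenyl groups differ only in their substitution pattern, and nothing measured here separates the two patterns. Compound 4 is therefore expected to show a modest rise in this assay, about a 6.2-fold higher number from compound 1 to compound 4 (0.79 log units; beyond the scatter). The estimate for compound 4 is 5000 nM, with a range from 1800 nM to 14000 nM.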

Compound 4, half-maximal inhibitory concentration: > 100000 nM
Compound 4 ended at the assay's limit (the forecaster's own chance of this, stated with the estimate: 5%); at least 20-fold (1.30 log units) between middle value and limit.
By their numbers in this assay, from the lowest: compounds 1 and 2 (each within the scatter of the next); then compound 3. At a limit, above all of these: compound 4.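

In this assay, compound 4 stands at a limit of the assay and not at a number: the limit of > 100000 nM in this assay, at which 1 of the 4 values shown sits. At the carbon with a double bond to nitrogen, the change from either dichlorophenyl group now gives a far larger step than the earlier replacements did, with an at least 120-fold higher number from compound 1 to compound 4 (2.09 log units; beyond the scatter) and an at least 70-fold higher number from compound 2 to compound 4 (1.85 log units; beyond the scatter). The two trimethoxyphenyl groups, which nothing had separated before, now part clearly, with an at least 14-fold higher number from compound 3 to compound 4 (1.17 log units; beyond the scatter), so at this place the arrangement of the methoxy groups matters in this assay, not only their presence.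

The compounds shown leave open whether a 3,4-dimethoxyphenyl or a 4-methoxyphenyl group at this place would stay near compound 3 or also reach the limit. They also leave open whether a 2,4-dimethoxyphenyl group, with the pattern of compound 1, would come closer to compound 1 than compound 3 does.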